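A new group on a carbonyl carbon, after three limits

The source may hold more compounds than are shown below. What is called first, only, known or untested is meant among the compounds shown, and "the series" means these compounds.

Of the compounds shown here, three sharing one core have been tested in a functional assay on RAW264.7 cells (Mus musculus) for inhibition, read by Griess assay, with stated times of 3 h and 24 h; a lower number here means a stronger inhibitor, a higher number a weaker inhibitor. Compound 1 `C=C1CC[C@H]2[C@@](C)(CCC(=O)N[C@@]2(C)COC(=O)c2cccnc2)[C@@H]1/C=C/C1=CCOC1=O` gives > 50000 nM, which is a limit and not a number. Compound 2 `C=C1CC[C@H]2[C@@](C)(CCC(=O)N[C@@]2(C)COC(=O)c2ccccc2)[C@@H]1/C=C/C1=CCOC1=O` gives > 50000 nM, also a limit. Compound 3 `C=C1CC[C@H]2[C@@](C)(CCC(=O)N[C@@]2(C)COC(=O)[C@H](N)CC(C)C)[C@@H]1/C=C/C1=CCOC1=O` gives > 50000 nM, again a limit. Compound 3 therefore has no exact place in the series and shares (the limit of > 50000 nM in this assay, at which 3 of the 3 values shown sit).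

Compound 4 `C=C1CC[C@H]2[C@@](C)(CCC(=O)N[C@@]2(C)COC(=O)CCCC[C@@H]2CCSS2)[C@@H]1/C=C/C1=CCOC1=O` makes one change to compound 3, on a carbonyl carbon, where the 1-amino-3-methylbutyl group leaves: a group of 9 heavy atoms (7 carbon, 2 sulfur; one five-membered non-aromatic ring with 2 hetero atoms) in place of a group of 6 heavy atoms (5 carbon, 1 nitrogen; no ring), on a carbonyl carbon.

Three measured swaps at this same place bear on the change: a step that the two limits leave unreadable from compound 1 to compound 2, a step that the two limits leave unreadable from compound 1 to compound 3 and a step that the two limits leave unreadable from compound 2 to compound 3. None of them has a readable size, and none gives a direction. The estimate therefore assumes no shift beyond the scatter in this assay, and the expected change is a number no higher from compound 3 to compound 4 (the limit leaves the size open). Another limit is the likeliest report. If a number is obtained, compound 4 is estimated at 50000 nM, with an expected range from 12000 nM to 100000 nM.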

Compound 4, half-maximal inhibitory concentration: 22400 nM
The estimate for compound 4 lay 2.2-fold (0.35 log units) above the measured number; low and high end bracket the measured number.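

Compound 4 alone among the four compounds gives a number rather than a limit in this assay, which shows that the group on this carbonyl carbon can move the read-out: there is an at least 2.2-fold lower number from compound 3 to compound 4 (0.34 log units; beyond the scatter) and an at least 2.2-fold lower number from compound 2 to compound 4 (0.34 log units; beyond the scatter) and an at least 2.2-fold lower number from compound 1 to compound 4 (0.34 log units; beyond the scatter). Within the data shown here, these steps are the first readable ones at this position, since the steps among compound 1, compound 2 and compound 3 cannot be read. Those three compounds share one limit, which is not a number: the limit of > 50000 nM in this assay, at which 3 of the 4 values shown sit.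

The compounds shown do not separate the effect of the five-membered ring with its two sulfur atoms from that of the carbon chain carrying it. A plain alkyl chain or a cyclopentyl ring on that chain would help to tell these two parts apart.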